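The source may report more compounds than this note shows. Statements on the series, on what has been measured and on what is new or still open speak of the compounds shown alone.

Of the compounds shown here, two have been measured. Compound 1 `COc1ccc(C(=O)NC[C@H]2c3[nH]c4ccccc4c3C[C@H]3[C@H]4c5[nH]c6ccccc6c5C[C@@H]([C@H](C#N)N23)N4C)cc1` gives 320 nM in a functional assay on BGC-823 cells (Homo sapiens) for cytotoxicity, read by MTT assay, with a stated time of 72 h; on this read-out higher numbers stand for weaker inhibition and lower numbers for stronger inhibition. Compound 2 `CN1[C@@H]2c3[nH]c4ccccc4c3C[C@H]1[C@H](C#N)N1[C@@H](CNC(=O)c3cc4ccccc4s3)c3[nH]c4ccccc4c3C[C@@H]21` gives 240 nM in this assay.

Compound 2 holds the lowest of the two numbers shown, though its nearest neighbour, compound 1, is separated from it by a 1.3-fold lower number from compound 1 to compound 2 (0.12 log units; within the scatter), a gap that falls within the scatter, so no order between the two can be claimed.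

Compound 3 `CN1[C@@H]2c3[nH]c4ccccc4c3C[C@H]1[C@H](C#N)N1[C@@H](CNC(=O)c3cc4ccccc4o3)c3[nH]c4ccccc4c3C[C@@H]21` has not yet been measured. It differs from compound 2 by 1-benzofuran-2-yl in place of 1-benzothiophen-2-yl on a carbonyl carbon. Within the data shown here, the only measured step that bears on the amide substituent is a 1.3-fold lower number from compound 1 to compound 2 (0.12 log units; within the scatter), which did not move the number beyond the scatter. On this basis the exchange of one bicyclic aromatic group for a closely related one is expected to leave this assay essentially unchanged, with no shift beyond the scatter, so the estimated step is a 1.3-fold higher number from compound 2 to compound 3 (0.10 log units; within the scatter). Compound 3 is therefore estimated at 300 nM, within a range of 150 nM to 600 nM.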

Compound 3, half-maximal inhibitory concentration: 210 nM
Beside the measured number, compound 3's estimate is 1.4-fold (0.15 log units) above it; the range from low to high includes it.
By their numbers in this assay, from the lowest: compounds 3, 2 and 1 (each within the scatter of the next).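

Replacing the sulfur of the 1-benzothiophen-2-yl group with the oxygen of 1-benzofuran-2-yl on this carbonyl carbon gives a 1.1-fold lower number from compound 2 to compound 3 (0.06 log units; within the scatter) in this assay, so this exchange of the ring hetero atom does not separate the two compounds. The step from the single-ring 4-methoxyphenyl group to 1-benzofuran-2-yl, a 1.5-fold lower number from compound 1 to compound 3 (0.18 log units; within the scatter), also stays within the scatter, so all three aromatic groups on this carbonyl carbon give indistinguishable numbers. Nothing available explains why these numbers remain so close.

The compounds shown leave open whether the number would hold with a piperidine, a carboxylic acid or a longer alkyl chain on this carbonyl carbon. They also leave open what part the nitrile plays, as all three compounds carry it on the shared core.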